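Notes on a short lipoamide nucleoside series, compound 4 pending

The source may report more compounds than this note shows. Statements on the series, on what has been measured and on what is new or still open speak of the compounds shown alone.

Measured so far:
compound 1, `CCCCCCCCCCCCCCCCCC(=O)N[C@@H](CCSC)C(=O)Nc1ccn([C@H]2O[C@@H](CO)[C@H](O)[C@H]2O)c(=O)n1`, gives 9000 nM in a functional assay on HeLa cells (Homo sapiens) for cytotoxicity, read by MTT assay, with a stated time of 48 h; a higher number here means a weaker inhibitor, a lower number a stronger inhibitor
compound 2, `CCCCCCCCCCCCCCCCCC(=O)N[C@@H](CCCNC(=N)N)C(=O)Nc1ccn([C@H]2O[C@@H](CO)[C@H](O)[C@H]2O)c(=O)n1`, gives 12100 nM
compound 3, `CCCCCCCCCCCCCC(=O)N[C@@H](CCCNC(=N)N)C(=O)Nc1ccn([C@H]2O[C@@H](CO)[C@H](O)[C@H]2O)c(=O)n1`, gives 32000 nM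

Compound 3 has the highest number of the three. Its core differs from that of compound 2 by hydrogen in place of butyl on a saturated chain carbon, ten or more bonds along the chain from a carbonyl carbon, which made a 2.6-fold higher number from compound 2 to compound 3 (0.42 log units; beyond the scatter). The change from compound 2 to compound 1 is a group of 2 heavy atoms (1 carbon, 1 sulfur; no ring) in place of a group of 5 heavy atoms (2 carbon, 3 nitrogen; no ring), on a saturated chain carbon, three bonds along the chain from an amide-type nitrogen and a carbonyl carbon, and it made a 1.3-fold lower number from compound 2 to compound 1 (0.13 log units; within the scatter).

Compound 4, `CCCCCCCCCCCCCC(=O)N[C@@H](CCSC)C(=O)Nc1ccn([C@H]2O[C@@H](CO)[C@H](O)[C@H]2O)c(=O)n1`, is not yet measured. It differs from compound 3 by a group of 2 heavy atoms (1 carbon, 1 sulfur; no ring) in place of a group of 5 heavy atoms (2 carbon, 3 nitrogen; no ring), on a saturated chain carbon, three bonds along the chain from an amide-type nitrogen and a carbonyl carbon, the same change at the same place as that from compound 2 to compound 1. Because a 1.3-fold lower number from compound 2 to compound 1 (0.13 log units; within the scatter) lies within the scatter, the step from compound 3 to compound 4 in this assay is expected to be similarly small, a 1.3-fold lower number from compound 3 to compound 4 (0.11 log units; within the scatter). Compound 4 is therefore estimated at 25000 nM, with a range from 12000 nM to 50000 nM.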

Compound 4, half-maximal inhibitory concentration: 8020 nM
Compound 4: middle estimate off by 3.1-fold (0.49 log units), on the high side; the whole stated range lies above it.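

In this assay, the change to methylsulfanyl on the core of compound 3 gives a 4.0-fold lower number from compound 3 to compound 4 (0.60 log units; beyond the scatter), so the step did not carry over in size from the other core: the same change on two cores in this assay, a 1.3-fold lower number (0.13 log units; within the scatter) from compound 2 to compound 1 and a 4.0-fold lower number (0.60 log units; beyond the scatter) from compound 3 to compound 4, 3.0-fold (0.47 log units) apart, beyond the scatter of two such steps. Hydrogen in place of butyl, with methylsulfanyl present, reads as a 1.1-fold lower number from compound 1 to compound 4 (0.05 log units; within the scatter), and this step also depends on the core: the same change on two cores in this assay, a 2.6-fold higher number (0.42 log units; beyond the scatter) from compound 2 to compound 3 and a 1.1-fold lower number (0.05 log units; within the scatter) from compound 1 to compound 4, 3.0-fold (0.47 log units) apart, beyond the scatter of two such steps. The two changes therefore do not add in these four compounds, but a single set of four shows neither the reason nor whether this holds for other groups or chains.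

Going by these compounds, whether an amine or a carboxylic acid on the same saturated chain carbon would follow compound 2 or compound 4 remains open. So does the behaviour of a longer chain.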